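A few compounds are considered here, and "the series" means these few. Any claim that something is new, unique, unknown or untested is made for them only; others in the source may bear on it.

Measured in a functional assay on MDA-MB-231 cells (Homo sapiens) for antiproliferative activity, read by MTT assay, with a stated time of 48 h; on this read-out higher numbers stand for weaker inhibition and lower numbers for stronger inhibition:
- compound 1 `C=CS(=O)(=O)N1CCN(c2ncnc3sc(-c4ccc(N5CCN(C)CC5)cc4)cc23)CC1`: 7550 nM
- compound 2 `C=CS(=O)(=O)N1CCN(c2nc(OC[C@H]3CCCN3C)nc3sc(-c4ccc(N5CCN(C)CC5)cc4)cc23)CC1`: 760 nM

Compound 2, at 760 nM, holds the lower of the two numbers in this assay. Compound 3 `C=CS(=O)(=O)N1CCN(c2nc(OC[C@H]3CCCN3C)nc3sc(-c4ccc(N5CCN(C)CC5)cc4)cc23)[C@@H](C)C1` is derived from compound 2 by one change: methyl in place of hydrogen on a saturated ring carbon. The 4-(vinylsulfonyl)piperazin-1-yl becomes 2-methyl-4-(vinylsulfonyl)piperazin-1-yl.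

Within the data shown here, only one measured step is available, a 9.9-fold lower number from compound 1 to compound 2 (1.00 log units; beyond the scatter). It is modest and concerns a (1-methylpyrrolidin-2-yl)methoxy in place of hydrogen on an aromatic carbon, so it bears only indirectly on this change. Among the measured compounds shown here, no measured pair tests a methyl on the saturated ring, and the direction remains open. No shift beyond the scatter is therefore expected, though the uncertainty is wide.

The estimated step is a 1.0-fold lower number from compound 2 to compound 3 (0.01 log units; within the scatter). For compound 3 the expected value is 750 nM, with an estimated range of 280 nM to 2000 nM.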

Compound 3, half-maximal inhibitory concentration: 2880 nM
Beside the measured number, compound 3's estimate is 3.8-fold (0.58 log units) below it; measured number above the stated range.
By their numbers in this assay, from the lowest: compound 2; then compound 3; then compound 1.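

In this assay, among these compounds, a methyl on the saturated ring carbon next to the ring nitrogen gives a 3.8-fold higher number from compound 2 to compound 3 (0.58 log units; beyond the scatter), the first measured change on this ring, with the (1-methylpyrrolidin-2-yl)methoxy and the rest of the molecule held constant. A single added carbon at this position therefore moves the number beyond the scatter and in the unfavourable direction, so the ring carbon is not a neutral place for substitution in this pair. Nothing available here accounts for the rise.

Open, from the compounds shown here alone, is whether the opposite configuration at the methyl-bearing carbon would give the same number, and whether an ethyl or a hydroxymethyl there would raise it further. Also open, going by these compounds, is whether the step would hold on the core of compound 1, which lacks the methoxy side chain.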